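This account rests on a few compounds, and the source may have more. Where it says the series, first, only, none or still open, it means among the compounds named here.

Measured in an assay on LtK cells with ATP-sensitive inward rectifier potassium channel 11 (Homo sapiens) as the target (a lower number here means that less compound is needed, a higher number that more compound is needed for the effect), so far:
- compound 1 `CCC(=O)Nc1c(C(O)(C(F)(F)F)C(F)(F)F)ccc2ccccc12`: 15 nM
- compound 2 `O=C(NCCCCCCCl)Nc1c(C(O)(C(F)(F)F)C(F)(F)F)ccc2ccccc12`: 4840 nM
- compound 3 `O=C(Nc1c(C(O)(C(F)(F)F)C(F)(F)F)ccc2ccccc12)c1cccc(Br)c1`: 80 nM

Compound 2 carries the highest number of the three, standing a 61-fold lower number from compound 2 to compound 3 (1.78 log units; beyond the scatter) from its nearest neighbour, and compound 1 sits lower still, as a 320-fold higher number from compound 1 to compound 2 (2.51 log units; beyond the scatter) shows. Compound 4 `O=C(Nc1c(C(O)(C(F)(F)F)C(F)(F)F)ccc2ccccc12)c1cc(Cl)cc(Cl)c1` differs from compound 2 by 3,5-dichlorophenyl in place of (6-chlorohexyl)amino on a carbonyl carbon. Going by the values given here, the step that bears directly on this is the one from compound 2 to compound 3, where an aryl group also took the place of the (6-chlorohexyl)amino and gave a 61-fold lower number from compound 2 to compound 3 (1.78 log units; beyond the scatter); the step of a 5.3-fold higher number from compound 1 to compound 3 (0.73 log units; beyond the scatter) shows that the aryl compound still sits above compound 1. A large drop in the number is therefore expected, a 48-fold lower number from compound 2 to compound 4 (1.68 log units; beyond the scatter). For compound 4 the expected value is 100 nM, with a range of 30 nM to 400 nM.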

Compound 4, half-maximal effective concentration: 306 nM
Compound 4: middle estimate off by 3.1-fold (0.49 log units), on the low side; the measured number falls inside the stated range.
By their numbers in this assay, from the lowest: compound 1; then compound 3; then compound 4; then compound 2.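

On the carbonyl carbon, a second aryl group again lowers the number relative to (6-chlorohexyl)amino in this assay (a 16-fold lower number from compound 2 to compound 4 (1.20 log units; beyond the scatter)), so this drop is not confined to the 3-bromophenyl of compound 3. The two aryl groups still differ, with 3,5-dichlorophenyl higher (a 3.8-fold higher number from compound 3 to compound 4 (0.58 log units; beyond the scatter)), and neither reaches the ethyl of compound 1 (a 20-fold higher number from compound 1 to compound 4 (1.31 log units; beyond the scatter)). No measurement available here explains this order.

Open: whether 3-chlorophenyl or 3,5-dibromophenyl separates the effect of the halogen from that of the substitution pattern, and how a propyl or cyclopropyl group compares with ethyl.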